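A Halogen Swap on the Aromatic Nitrogen Substituent

A few compounds are considered here, and "the series" means these few. Any claim that something is new, unique, unknown or untested is made for them only; others in the source may bear on it.

Compound 1, `CNC(=O)c1cc(Oc2ccc(NC(=O)c3cc4cccnc4n(-c4ccccc4F)c3=O)cc2)ccn1`, gives 260 nM in a functional assay on HT-29 cells (Homo sapiens) for antiproliferative activity, read by MTT assay, with a stated time of 72 h; a lower number here means a stronger inhibitor, a higher number a weaker inhibitor.
Compound 2, `CNC(=O)c1cc(Oc2ccc(NC(=O)c3cc4cccnc4n(-c4ccc(Cl)cc4)c3=O)cc2)ccn1`, gives 390 nM in this assay.

Compound 1 holds the lowest of the two numbers, and compound 2 is the nearest. Among the compounds with values here, the only measured step between them is a 1.5-fold higher number from compound 1 to compound 2 (0.18 log units; within the scatter), which falls within the scatter, so the two compounds cannot be told apart on these data.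

Compound 3, `CNC(=O)c1cc(Oc2ccc(NC(=O)c3cc4cccnc4n(-c4ccc(Br)cc4)c3=O)cc2)ccn1`, is not yet measured. It differs from compound 1 by 4-bromophenyl in place of 2-fluorophenyl on an aromatic nitrogen. The measured step that bears on this change is a 1.5-fold higher number from compound 1 to compound 2 (0.18 log units; within the scatter), where another 4-halophenyl took the place of the same 2-fluorophenyl on the same aromatic nitrogen and produced no shift beyond the scatter. On that basis the step of a 1.5-fold higher number from compound 1 to compound 3 (0.16 log units; within the scatter) is expected to be small, with at most a slight rise in the number. Compound 3 is therefore estimated to give 380 nM in this assay, with a range from 180 nM to 800 nM.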

Compound 3, half-maximal inhibitory concentration: 1180 nM
The estimate for compound 3 lay 3.1-fold (0.49 log units) below the measured number; measured number above the stated range.
By their numbers in this assay, from the lowest: compounds 1 and 2 (each within the scatter of the next); then compound 3.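

In this assay, bromo in place of chloro on the 4-halophenyl group gives a 3.0-fold higher number from compound 2 to compound 3 (0.48 log units; beyond the scatter) and so goes beyond the scatter, although only one halogen atom has changed. Replacing 2-fluorophenyl with 4-bromophenyl gives a 4.5-fold higher number from compound 1 to compound 3 (0.66 log units; beyond the scatter) and also goes beyond the scatter, so the group on this aromatic nitrogen tolerates less change than compounds 1 and 2 alone suggested. No measurement shown here explains why bromo gives a higher number than chloro at this place.

Compound 1 differs from compounds 2 and 3 in both the halogen and where it sits on the phenyl group, so the two effects cannot be separated here. Whether any halogen is needed also remains open, as a plain phenyl, 4-fluorophenyl, 2-bromophenyl and 4-methoxyphenyl are not among the compounds shown.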